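The source may report more compounds than this note shows. Statements on the series, on what has been measured and on what is new or still open speak of the compounds shown alone.

Measured compounds:
Compound 1, `CCOc1ncc(-c2nc(C(F)(F)F)sc2N2CCN(C(=O)Cn3c(=O)oc4ccccc43)[C@H](C)C2)cn1`, gives 3.3 nM in a functional assay on CHO-K1 cells for antagonist activity at C-X-C chemokine receptor type 3 (Homo sapiens), read by FLIPR, with a stated time of 10 min; a higher number here means a weaker inhibitor, a lower number a stronger inhibitor.
Compound 2, `CCOc1ncc(-c2nc(C(F)(F)F)sc2N2CCN(C(=O)Cn3nc(C)cc3C)[C@H](C)C2)cn1`, gives 2.3 nM in this assay.
Compound 3, `CCOc1ncc(-c2nc(C(F)(F)F)sc2N2CCN(C(=O)Cn3nc(C)nc3C)[C@H](C)C2)cn1`, gives 7 nM in this assay.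

Compound 3 carries the highest number of the three: a 2.1-fold higher number from compound 1 to compound 3 (0.33 log units; beyond the scatter) and a 3.0-fold higher number from compound 2 to compound 3 (0.48 log units; beyond the scatter), both beyond the scatter, while a 1.4-fold lower number from compound 1 to compound 2 (0.16 log units; within the scatter) stays within it. All three measured steps concern the group on the saturated chain carbon bound to the carbonyl carbon; the shared core and the 2-ethoxypyrimidin-5-yl group are untouched in every one of them.

Compound 4, `CCCc1ncc(-c2nc(C(F)(F)F)sc2N2CCN(C(=O)Cn3nc(C)nc3C)[C@H](C)C2)cn1`, keeps the acetamide side of compound 3 unchanged and alters the other end: propyl in place of ethoxy on an aromatic carbon. No measured step touches this part of the molecule, so the size and direction of the effect cannot be read from the steps shown. With nothing in the data pointing either way, the number for compound 4 in this assay is expected to stay near that of compound 3, with the estimate no change at the digits printed from compound 3 to compound 4 (within the scatter) reflecting that absence of a lead. The estimated value for compound 4 is 7 nM, within a range from 2.5 nM to 20 nM.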

Compound 4, half-maximal inhibitory concentration: 4.4 nM
Beside the measured number, compound 4's estimate is 1.6-fold (0.20 log units) above it; the range from low to high includes it.
By their numbers in this assay, from the lowest: compounds 2, 1, 4 and 3 (each within the scatter of the next, the first and the last beyond it).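

The first step read at this position, on an aromatic carbon between two ring nitrogen atoms, is a 1.6-fold lower number from compound 3 to compound 4 (0.20 log units; within the scatter) in this assay. Propyl in place of ethoxy keeps the count of heavy atoms and drops the oxygen with its hydrogen-bond acceptor, yet compound 3 and compound 4 are not separated in this read-out, so for this pair the oxygen is not needed to hold the number in the low nanomolar range. No further data bear on this result.

From the compounds shown here alone, the reading rests on one pair carrying the 3,5-dimethyl-1H-1,2,4-triazol-1-yl group, so whether the exchange reads the same with the other groups of compound 1 and compound 2 remains open. Going by these compounds, how an amine, a carboxylic acid or a longer chain on this aromatic carbon would read also remains open.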